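A few compounds are considered here, and "the series" means these few. Any claim that something is new, unique, unknown or untested is made for them only; others in the source may bear on it.

Of the compounds shown here, two have been measured in an ADME assay on HUVEC cells (Homo sapiens) for cytotoxicity, read by MTT assay, with a stated time of 48 h; a lower number here means a stronger inhibitor, a higher number a weaker inhibitor. Compound 1 `COc1ccc(-c2cn(/N=C/c3cc4ccccc4nc3Cl)c(N)n2)cc1` gives 12400 nM, and compound 2 `Nc1nc(-c2ccc(Cl)cc2)cn1/N=C/c1cc2ccccc2nc1Cl` gives 28000 nM. Going by the values given here, compound 2 therefore stands with the highest of the two numbers, the weaker of the pair in this assay, and compound 1 is its only neighbour. Compound 3 `Nc1nc(-c2ccc(Br)cc2)cn1/N=C/c1cc2ccccc2nc1Cl` differs from compound 2 by a single exchange: bromo in place of chloro on an aromatic carbon, on an aromatic carbon of a six-membered aromatic ring of carbon only, para to a large group. Among the compounds with values here, no measured pair shows this particular exchange. Within the data shown here, the one recorded step, a 2.3-fold higher number from compound 1 to compound 2 (0.35 log units; beyond the scatter), replaced a methoxy group with a halogen and was modest; exchanging one halogen for another at the same place is a smaller change than that. In this assay the step from compound 2 to compound 3 is therefore expected to stay within the scatter, no change at the digits printed from compound 2 to compound 3 (within the scatter). Compound 3 is estimated at 28000 nM, within a range from 14000 nM to 56000 nM.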

Compound 3, half-maximal inhibitory concentration: 11900 nM
Compound 3: middle estimate off by 2.4-fold (0.37 log units), on the high side; measured number below the stated range.
By their numbers in this assay, from the lowest: compounds 3 and 1 (each within the scatter of the next); then compound 2.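

In this assay, exchanging one halogen for another at this place, para to a large group, is not a silent change: going from chloro to bromo gives a 2.4-fold lower number from compound 2 to compound 3 (0.37 log units; beyond the scatter), a modest step of the same order as the one between methoxy and chloro. Bromo and methoxy, by contrast, read alike here, with a 1.0-fold lower number from compound 1 to compound 3 (0.02 log units; within the scatter), so the three compounds do not sort into halogens on one side and methoxy on the other; compound 3, with its bromo, goes against such a split, and compound 2, with its chloro, is the one that stands apart. Nothing available here offers a measured explanation of why the chloro compound separates from the other two.

As far as these compounds go, with only methoxy, chloro and bromo seen on this aromatic carbon, it remains open whether fluoro, an amine or a carboxylic acid at the same place would read with compound 2 or with compound 1 and compound 3. From the compounds shown here alone, it also remains open whether the exchange from 4-chlorophenyl to 4-bromophenyl would give a similar step on a different core.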